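A few compounds are considered here, and "the series" means these few. Any claim that something is new, unique, unknown or untested is made for them only; others in the source may bear on it.

Measured so far in a functional assay on NPC-TW01 cells (Homo sapiens) for inhibition, read by MTT assay, with a stated time of 72 h; on this read-out higher numbers stand for weaker inhibition of growth and lower numbers for stronger inhibition of growth:
Compound 1 `CCc1nc(C(=O)OC)nn1-c1ccc(F)cc1` gives 15800 nM.
Compound 2 `CCCCc1nc(C(=O)OC)nn1-c1ccc(F)cc1` gives only a limit, > 100000 nM, not a number.
Compound 3 `COC(=O)c1nc(C2CCCC2)n(-c2ccc(F)cc2)n1` gives 10400 nM.

Of the two numbers, compound 3 has the lower one, but the step of a 1.5-fold lower number from compound 1 to compound 3 (0.18 log units; within the scatter) stays within the scatter, so no order between these two can be claimed.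

Compound 4 `COC(=O)c1nc(-c2ccsc2)n(-c2ccc(F)cc2)n1` differs from compound 3 by thiophen-3-yl in place of cyclopentyl on an aromatic carbon.

Two measured steps change the group at this same aromatic carbon: a 1.5-fold lower number from compound 1 to compound 3 (0.18 log units; within the scatter) and an at least 9.6-fold lower number from compound 2 to compound 3 (0.98 log units; beyond the scatter). Neither swaps the cyclopentyl for an aromatic ring, so the nearest guide is the small move between compound 1 and compound 3. For compound 4 no step beyond the scatter is expected in this assay, in either direction.

Compound 4 is estimated at 12000 nM, between 4000 nM and 40000 nM. The expected step is a 1.2-fold higher number from compound 3 to compound 4 (0.06 log units; within the scatter).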

Compound 4, concentration for 50% growth inhibition: 10700 nM
Compound 4: the middle estimate sits 1.1-fold (0.05 log units) above what was measured, within the range that was stated.
By their numbers in this assay, from the lowest: compounds 3, 4 and 1 (each within the scatter of the next). At a limit, above all of these: compound 2.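

In this assay, an aromatic ring carrying sulfur at this aromatic carbon reads the same as the saturated cyclopentyl ring (a 1.0-fold higher number from compound 3 to compound 4 (0.01 log units; within the scatter)), so this ring need not be saturated for the number to hold. Thiophen-3-yl also stays level with ethyl (a 1.5-fold lower number from compound 1 to compound 4 (0.17 log units; within the scatter)). It separates clearly only from butyl (an at least 9.3-fold lower number from compound 2 to compound 4 (0.97 log units; beyond the scatter)), and that step rests on a limit for compound 2: the limit of > 100000 nM in this assay, at which 1 of the 4 values shown sits.

From the compounds shown here alone, whether a phenyl ring or a ring bearing an amine would hold at this carbon stays open. So does what a carboxylic acid would do in place of the methoxycarbonyl group.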